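The source may hold more compounds than are shown below. What is called first, only, known or untested is meant among the compounds shown, and "the series" means these compounds.

Compound 1 has the structure `CCCCCCC(CCO)n1cnc2c(N)ncnc21`. In a functional assay on HCT-116 cells (Homo sapiens) for antiproliferative activity, read by MTT assay, with a stated time of 48 h (on this read-out lower numbers stand for stronger inhibition and higher numbers for weaker inhibition), compound 1 gives > 50000 nM, which is a limit of the assay rather than a number. Compound 2, `CCCCCCC(CCO)n1cnc2c(N)nc(Cl)nc21`, carries one change relative to compound 1: chloro in place of hydrogen on an aromatic carbon. In this assay compound 2 gives > 50000 nM, again a limit. The step that the two limits leave unreadable from compound 1 to compound 2 cannot be sized because of the limit of > 50000 nM in this assay, at which 3 of the 3 values shown sit. Compound 3, `CCCCCCCC(CCO)n1cnc2c(N)ncnc21`, differs from compound 1 in another way: methyl in place of hydrogen on a saturated chain carbon, seven bonds along the chain from an aromatic nitrogen. In this assay compound 3 gives > 50000 nM, also a limit. The step that the two limits leave unreadable from compound 1 to compound 3 is likewise unreadable because of the limit of > 50000 nM in this assay, at which 3 of the 3 values shown sit.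

Compound 4, `CCCCCCCC(CCO)n1cnc2c(N)nc(Cl)nc21`, has not yet been measured. It stands to compound 3 as compound 2 stands to compound 1: chloro in place of hydrogen on an aromatic carbon. The place of the entering group is described in the same words in both cases, so this is the same change seen a second time. Among the compounds with values here, its only measured instance has already been described: the two limits leave its size unreadable, so nothing about the direction or magnitude of this change has been learned yet.

With compound 3 itself sitting at the limit and no readable movement from the same change elsewhere, compound 4 is expected to show a step that the limit leaves unreadable from compound 3 to compound 4 in this assay. Compound 4 is therefore estimated at 80000 nM in this assay, most likely reported only as a limit, with a plausible range from 20000 nM to 300000 nM.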

Compound 4, half-maximal inhibitory concentration: > 50000 nM
Compound 4: a limit, no number (the forecaster's own chance of this, stated with the estimate: 85%); the middle value lies beyond the limit too.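

Compound 4 gives a limit rather than a number, so neither the step to it from compound 3 nor the step to it from compound 2 can be read, because every compound shown sits at the same limit: the limit of > 50000 nM in this assay, at which 4 of the 4 values shown sit.

The compounds shown leave open whether chloro in place of hydrogen, or the added methyl on the chain, changes the result in this assay at all, and in which direction.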